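Trimethoxybenzyl analogue: expectation from the dimethoxy compound

A few compounds are considered here, and "the series" means these few. Any claim that something is new, unique, unknown or untested is made for them only; others in the source may bear on it.

In a functional assay on IGROV-1 cells (Homo sapiens) for inhibition, read by sulforhodamine B assay, with a stated time of 48 h (on this read-out lower numbers stand for stronger inhibition of growth and higher numbers for weaker inhibition of growth), compound 1 `Nc1cc(N)c2nc(-c3ccccc3)c(Oc3ccc(Cl)c(Cl)c3)nc2c1` gives 32400 nM, compound 2 `Nc1cc(N)c2nc(-c3ccccc3)c(NCc3ccc(Cl)c(Cl)c3)nc2c1` gives 5890 nM, and compound 3 `COc1ccc(CNc2nc3cc(N)cc(N)c3nc2-c2ccccc2)cc1OC` gives 40700 nM. For the measured compounds named here, the numbers of compound 3 and compound 1 lie within the scatter of each other; the only measured step is a 6.9-fold higher number from compound 2 to compound 3 (0.84 log units; beyond the scatter), a change beyond the scatter. Compound 4 `COc1cc(CNc2nc3cc(N)cc(N)c3nc2-c2ccccc2)cc(OC)c1OC` differs from compound 3 by methoxy in place of hydrogen on an aromatic carbon. Going by the values given here, no measured step covers the addition of a methoxy group; the one step available exchanged whole aryl groups and does not bear on this change. In this assay the expected outcome is a 1.0-fold lower number from compound 3 to compound 4 (0.01 log units; within the scatter), a step within the scatter. Compound 4 is estimated at 40000 nM, with a range from 15000 nM to 110000 nM.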

Compound 4, concentration for total growth inhibition: < 50200 nM
Compound 4: a limit, no number; the forecaster's own chance of this, stated with the estimate: 10%; the middle value is on the limit's open side.
By their numbers in this assay, from the lowest: compound 2; then compounds 1 and 3 (each within the scatter of the next).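

In this assay, for the compounds shown here, compound 4 gives < 50200 nM, a limit and not a number, so no step from compound 3 to compound 4 can be read. The compounds shown leave open whether methoxy in place of hydrogen on the aromatic carbon changes growth inhibition.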